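From trifluoromethoxy to cyclopropyl in compound 4

This account rests on a few compounds, and the source may have more. Where it says the series, first, only, none or still open, it means among the compounds named here.

- compound 1 `COc1cccc(NC(=O)c2nnn(CC3CCN(C(C)=O)CC3)c2N)c1` gives 1.2
- compound 2 `COc1cccc(NC(=O)c2nnn(Cc3ccc(C(C)C)cc3)c2N)c1` gives 3.4
- compound 3 `COc1cccc(NC(=O)c2nnn(Cc3ccc(OC(F)(F)F)cc3)c2N)c1` gives 3.6

All three were measured in a physicochemical assay for lipophilicity, read by HPLC, measured as chromatographic lipophilicity, at pH 7.4 (on this read-out lower numbers stand for lower lipophilicity and higher numbers for higher lipophilicity), and share one core. Compound 3 stands at the upper end of these numbers together with compound 2, and the step between them is a number 0.20 log units higher from compound 2 to compound 3 (within the scatter). Compound 1 lies well under both. Compound 4 `COc1cccc(NC(=O)c2nnn(Cc3ccc(C4CC4)cc3)c2N)c1` has cyclopropyl in place of trifluoromethoxy on an aromatic carbon, para to a large group (cyclopropyl in place of trifluoromethoxy on an aromatic carbon). The closest evidence is the exchange at that aromatic carbon, where compound 2 carries isopropyl, like cyclopropyl a group of carbon only, and gives 3.4 in this assay. The large step, a number 2.20 log units higher from compound 1 to compound 2 (beyond the scatter), concerns a different exchange and says little here. A small downward change is therefore expected, and the estimated step is a number 0.30 log units lower from compound 3 to compound 4 (within the scatter). For compound 4 the estimate is 3.3, with an expected range from 3 to 3.6.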

Compound 4, distribution coefficient: 3.2
Beside the measured number, compound 4's estimate is 0.10 log units above it, within the range that was stated.
By their numbers in this assay, from the lowest: compound 1; then compounds 4, 2 and 3 (each within the scatter of the next, the first and the last beyond it).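

In this assay, this aromatic carbon now gives a step beyond the scatter, as cyclopropyl in place of trifluoromethoxy gives a modest change (a number 0.40 log units lower from compound 3 to compound 4 (beyond the scatter)), whereas the earlier exchange here, between isopropyl and trifluoromethoxy, stayed within it. Cyclopropyl and isopropyl, the two groups of carbon only, cannot be told apart at this position (a number 0.20 log units lower from compound 2 to compound 4 (within the scatter)), and the large gap to the compound with 1-acetylpiperidin-4-yl remains with cyclopropyl in place (a number 2.00 log units higher from compound 1 to compound 4 (beyond the scatter)). Nothing at hand accounts for these steps.

Still open, on these data alone, is how an amine or a carboxylic acid on this aromatic carbon would read in this assay. Also open, as far as these compounds go, is whether a longer chain such as n-butyl would fall with isopropyl and cyclopropyl or stand apart from them.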